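This account rests on a few compounds, and the source may have more. Where it says the series, first, only, none or still open, it means among the compounds named here.

Notes on the series, read in a functional assay on CWR22R cells (Homo sapiens) for antiproliferative activity, read by CCK-8 assay, with a stated time of 6 days; a lower number here means a stronger inhibitor, a higher number a weaker inhibitor. Compound 1 `N#Cc1ccc(N2CCc3cc(-c4cnc5ccccc5c4)ccc3C2)cc1C(F)(F)F` gives 25900 nM. Compound 3 `N#Cc1ccc(N2CCc3cc(-c4cccnc4)ccc3C2)cc1C(F)(F)F` gives 4790 nM. Among the measured compounds shown here, the single measured step between them is a 5.4-fold lower number from compound 1 to compound 3 (0.73 log units; beyond the scatter). Compound 2 `CCN(c1ccc(C#N)c(Cl)c1)c1cc(-c2ccoc2)ccc1C` is built on a different core. For compound 2 this assay reports only a limit, > 30000 nM, so compound 2 sits at the limit of the numbers shown and no finer placing is possible. Compound 4 `CCN(c1ccc(C#N)c(Cl)c1)c1cc(-c2ccnn2C)ccc1C` differs from compound 2 in one place: 1-methyl-1H-pyrazol-5-yl in place of furan-3-yl on an aromatic carbon. For the measured compounds named here, the only measured step, from compound 1 to compound 3, sits on the other core and exchanges quinolin-3-yl for pyridin-3-yl, so it bears on the present change only loosely; the exchange of one five-membered ring for another is a smaller move than that one, and it gives no direction for the pyrazole. Going by the values given here, no measured step starts from a compound standing at the limit, and the sole footing for compound 2 is the limit of > 30000 nM in this assay, at which 1 of the 3 values shown sits. The expected outcome in this assay is a step of a number no higher from compound 2 to compound 4 (the limit leaves the size open), with a real chance that compound 4 again returns only a limit rather than a number. The estimate for compound 4 is 30000 nM, within 8000 nM to 100000 nM.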

Compound 4, half-maximal inhibitory concentration: 4330 nM
The estimate for compound 4 lay 6.9-fold (0.84 log units) above the measured number; the whole stated range lies above it.
By their numbers in this assay, from the lowest: compounds 4 and 3 (each within the scatter of the next); then compound 1. At a limit, above all of these: compound 2.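

In this assay, 1-methyl-1H-pyrazol-5-yl in place of furan-3-yl, on an aromatic carbon meta to a large group and para to a methyl group, gives an at least 6.9-fold lower number from compound 2 to compound 4 (0.84 log units; beyond the scatter), so activity on the core of compound 2 depends on which five-membered aromatic ring stands at this position. Among the compounds shown here, this is the first number on that core, with compound 4 at 4330 nM, whereas the only earlier measured step lay on the other core and involved different rings. The true size of the step stays unknown because compound 2 gives only a limit, not a number: the limit of > 30000 nM in this assay, at which 1 of the 4 values shown sits.

The exchange alters the hetero atoms of the ring and adds a methyl group in one move, so the compounds shown do not separate these two parts; an unmethylated pyrazole or a 1-methylpyrazole joined through another ring carbon would be needed to do so. As far as these compounds go, it also remains open whether a more distant kind of group at this position, such as an amine or a carboxylic acid, would be tolerated, and whether the pyrazole would give a similar result on the core of compound 1.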